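The source may report more compounds than this note shows. Statements on the series, on what has been measured and on what is new or still open speak of the compounds shown alone.

Measured so far in the cytotoxicity series:
compound 1 `CCOC(=O)/C=C/c1ccc(OC(=O)c2nc(C)c(C)nc2C)c(O)c1` — 207%
compound 2 `Cc1nc(C)c(C(=O)Oc2ccc(/C=C/C(=O)O)cc2)nc1C` — 46.6%

In a functional assay on EA.hy 926 cells (Homo sapiens) for cytotoxicity, read by MTT assay, with stated times of 24 h and 12 h, tested at 25 uM (a lower number here means a weaker effect, a higher number a stronger effect of the compound at the concentration tested), compound 2 stands lowest of the two numbers; compound 1 sits higher by a margin well beyond the scatter. Compound 3 `Cc1nc(C)c(C(=O)Oc2ccc(/C=C/C(=O)O)cc2O)nc1C` differs from compound 2 by hydroxy in place of hydrogen on an aromatic carbon. Among the compounds with values here, no pair of measured compounds isolates this single change, so its size is uncertain. Compound 1, which also carries a hydroxy alongside other differences, gives 207% in this assay. A step upward, beyond the scatter, is expected: a number 48.4 percentage points higher from compound 2 to compound 3 (beyond the scatter). Compound 3 is estimated at 95%, within a range of 45% to 180%.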

Compound 3, a percentage reported as activity, at one concentration (the size of the read-out at that concentration, not a potency): 271%
Estimate against measurement, compound 3: 176 percentage points below; the whole stated range lies below it.
By their numbers in this assay, from the lowest: compound 2; then compound 1; then compound 3.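

In this assay, hydroxy in place of hydrogen on an aromatic carbon, ortho to a large group and meta to a 2-carboxyethenyl group, now has an isolated reading: a number 224.4 percentage points higher from compound 2 to compound 3 (beyond the scatter) for this single change. With that hydroxy kept, hydrogen in place of ethyl on the oxygen next to the carbonyl group gives a number 64 percentage points higher from compound 1 to compound 3 (beyond the scatter) in the same direction, so the high reading does not depend on the ethyl group. On these data alone, whether a methoxy group or an amine at this position would give a step of similar size remains open. No measured evidence at hand explains either step.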